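The compounds below may be only part of what the source reports. "The series", "measured", "known", "first", "only" and "open" are said of these compounds alone.

Three compounds share one measured set of results. Compound 1 `CCN(CC)Cc1ccc(Nc2nc3ccccc3n2Cc2ccc(C#N)cc2)cc1O`, compound 3 `CCN(CC)Cc1ccc(Nc2nc3ccccc3n2Cc2ccc(F)cc2)cc1O` and compound 2 `CCN(CC)Cc1cc(Nc2nc3ccccc3n2Cc2ccc(F)cc2)ccc1O` were all tested in an ADME assay on CHO cells (Cricetulus griseus) for inhibition, read by MTT assay; a higher number here means a weaker inhibitor, a lower number a stronger inhibitor. Compound 3 gives 45800 nM, compound 1 gives 39000 nM and compound 2 gives 12000 nM. Compound 1 and compound 3 differ in one place: cyano in place of fluoro on an aromatic carbon. The step that this change made is a 1.2-fold lower number from compound 3 to compound 1 (0.07 log units; within the scatter). Compound 2 has the same atoms as compound 3 joined differently; the difference between the two cores is not broken down here. Compound 2 stands lowest of the three numbers, beyond the scatter from both compound 1 and compound 3.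

Compound 4 `CCN(CC)Cc1cc(Nc2nc3ccccc3n2Cc2ccc(C#N)cc2)ccc1O` has not yet been measured in this assay. It is related to compound 2 by cyano in place of fluoro on an aromatic carbon, the same change that took compound 3 to compound 1, at the same place. Because the earlier step was a 1.2-fold lower number from compound 3 to compound 1 (0.07 log units; within the scatter) and stayed within the scatter, the same change on the core of compound 2 is expected to leave the number close to that of compound 2. For compound 4 the step expected from this change is a 1.2-fold lower number from compound 2 to compound 4 (0.08 log units; within the scatter). On that basis compound 4 is expected to give about 10000 nM in this assay, most likely between 4000 nM and 25000 nM.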

Compound 4, half-maximal inhibitory concentration: > 50000 nM
Compound 4 ended at the assay's limit; the forecaster's own chance of this, stated with the estimate: 5%; middle value at least 5.0-fold (0.69 log units) from the limit.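

Carried to the other core, the change from 4-fluorobenzyl to 4-cyanobenzyl gave an at least 4.1-fold higher number from compound 2 to compound 4 (0.61 log units; beyond the scatter) in this assay, so the two cores did not respond to it alike: the same change on two cores in this assay, a 1.2-fold lower number (0.07 log units; within the scatter) from compound 3 to compound 1 and an at least 4.1-fold higher number (0.61 log units; beyond the scatter) from compound 2 to compound 4, at least 4.8-fold (0.68 log units) apart, beyond the scatter of two such steps

Compound 4 gives > 50000 nM, which is a limit of the assay and not a number, so only the lower end of this step is known and not its full size: the limit of > 50000 nM in this assay, at which 1 of the 4 values shown sits.

Across these four compounds, the result shows that a step measured on one core did not predict the step on the other, but it rests on a single pair of pairs and does not show which difference between the cores is responsible or how the change would behave on any further core.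

Going by these compounds, it remains open whether chloro or methoxy in the same place on the aromatic ring would follow fluoro or cyano on each of the two cores. On these data alone, it is also open whether a morpholine in place of the diethylamine would change the gap between the two cores.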